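The source may hold more compounds than are shown below. What is called first, only, known or untested is meant among the compounds shown, and "the series" means these compounds.

Measured in a functional assay on HUVEC cells (Homo sapiens) for cytotoxicity; a higher number here means that more compound is needed for the effect, a lower number that less compound is needed:
- compound 1 `COC1=C(C)C(=O)/C(=C(O)/C=C/c2ccc(C)cc2)C(=O)C1(C)C`: 2.4 ug/mL
- compound 2 `COC1=C(C)C(=O)/C(=C(O)/C=C/c2cccc3ccccc23)C(=O)C1(C)C`: 1.8 ug/mL

Compound 1 lies within the scatter of compound 2, so the two carry no order. Compound 3 `COC1=C(C)C(=O)/C(=C(O)/C=C/c2nccs2)C(=O)C1(C)C` has 1,3-thiazol-2-yl in place of 4-methylphenyl on a double-bonded chain carbon bound to a double-bonded chain carbon. Among the measured compounds shown here, no measured step covers this change. For the measured compounds named here, the only guide is that compound 2, at 1.8 ug/mL, stays within the scatter of compound 1 despite a different group on the chain. In this assay, no step beyond the scatter is therefore expected, with a slight lean towards a higher number. The expected change is a 1.3-fold higher number from compound 1 to compound 3 (0.10 log units; within the scatter). Compound 3 is estimated at 3 ug/mL, with an expected range of 1.2 ug/mL to 7 ug/mL.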

Compound 3, concentration for half-maximal effect: 1.6 ug/mL
Estimate against measurement, compound 3: 1.9-fold (0.27 log units) above; measured number inside the range.
By their numbers in this assay, from the lowest: compounds 3, 2 and 1 (each within the scatter of the next).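

The step of a 1.5-fold lower number from compound 1 to compound 3 (0.18 log units; within the scatter) shows that in this assay the place on a double-bonded chain carbon bound to a double-bonded chain carbon accepts 1,3-thiazol-2-yl in place of 4-methylphenyl without a step beyond the scatter. A five-membered aromatic ring with 2 hetero atoms and 2 hydrogen-bond acceptors therefore fits here, with fewer heavy atoms than the group it replaces. Nothing available explains this result.

Still open, from the compounds shown here alone, is whether a non-aromatic group such as cyclohexyl, or a phenyl ring carrying an amine or a carboxylic acid, would also stay within the scatter at this place.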